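A few compounds are considered here, and "the series" means these few. Any claim that something is new, unique, unknown or untested is made for them only; others in the source may bear on it.

The compounds here share one core, shown for compound 1 as `O=C1c2ccccc2N(COCc2ccccc2)S(=O)(=O)N1Cc1ccccc1`, and differ only in the groups on its two ring nitrogens. Compound 1 gives 122000 nM in a functional assay on HEL cells (Homo sapiens); a lower number here means that less compound is tolerated, a higher number that more compound is tolerated. Compound 2, `O=C1c2ccccc2N(Cc2ccccc2)S(=O)(=O)N1Cc1ccc(Cl)cc1`, gives 20000 nM in this assay. Compound 3, `O=C1c2ccccc2N(Cc2ccccc2)S(=O)(=O)N1Cc1ccccc1`, reaches only a limit of the measurement in this assay, namely > 50000 nM, which is the limit of > 50000 nM in this assay, at which 1 of the 3 values shown sits. The step that the limit leaves unreadable from compound 1 to compound 3 therefore cannot be read. The step of an at least 2.5-fold higher number from compound 2 to compound 3 (0.39 log units; beyond the scatter) can be read as a lower bound: taking away one chloro raised the tolerated amount by that much or more.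

Compound 4, `O=C1c2ccccc2N(Cc2ccc(Cl)c(Cl)c2)S(=O)(=O)N1Cc1ccccc1`, is compound 3 changed in one place: 3,4-dichlorophenyl in place of phenyl on a saturated chain carbon bound to a sulfonamide nitrogen in a ring. This runs opposite to the measured step from compound 2 to compound 3, which removed a chloro; here two chloro atoms are added on the same benzyl. From that single comparison a lower number is expected for compound 4, with a drop plausibly as large as the rise seen in an at least 2.5-fold higher number from compound 2 to compound 3 (0.39 log units; beyond the scatter), and since compound 3 is known only by a limit, the size is uncertain. For compound 4 the expected step is an at least 3.3-fold lower number from compound 3 to compound 4 (0.52 log units; beyond the scatter). Compound 4 is estimated at 15000 nM in this assay, with a range from 5000 nM to 50000 nM.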

Compound 4, minimum cytotoxic concentration: 200000 nM
Estimate against measurement, compound 4: 13-fold (1.12 log units) below; the whole stated range lies below it.
By their numbers in this assay, from the lowest: compound 2; then compounds 1 and 4 (each within the scatter of the next).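

In this assay compound 4 gives 200000 nM, so a benzyl carrying two chloro atoms on this ring nitrogen is compatible with a high tolerated amount, and the chloro step seen earlier does not predict this position, since the chloro of compound 2 sits on the benzyl of the other ring nitrogen. The comparison that can be read shows a 1.6-fold higher number from compound 1 to compound 4 (0.21 log units; within the scatter), so 3,4-dichlorophenyl and benzyloxy on this saturated chain carbon cannot be told apart in this assay, even though they are quite different groups. The direct effect of adding the two chloro atoms remains unknown, as the step from compound 3, whose value is only a limit, cannot be read: the limit of > 50000 nM in this assay, at which 1 of the 4 values shown sits.

The compounds shown do not separate the contribution of each chloro, as no benzyl with a single chloro on this ring nitrogen appears among them. On these data alone, it also remains open whether an amine or a carboxylic acid on this benzyl, or a longer chain between the ring nitrogen and the phenyl, would leave the number this high.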